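Swapping a Difluorophenyl Ring for a Methoxypropenyl Chain

This account rests on a few compounds, and the source may have more. Where it says the series, first, only, none or still open, it means among the compounds named here.

Of the compounds shown here, two built on one shared core have so far been tested in an assay on isolated protein with Bile acid receptor (Homo sapiens) as the target; a lower number here means that less compound is needed, a higher number that more compound is needed for the effect. Compound 1 `COC(=O)/C=C/c1cccc(N(Cc2ccc(/C=C/c3cc(C(F)(F)F)cc(C(F)(F)F)c3)cc2)C(=O)C2CCCCC2)c1` gives 1470 nM. Compound 2 `COC(=O)/C=C/c1cccc(N(Cc2ccc(-c3ccc(F)c(F)c3)cc2)C(=O)C2CCCCC2)c1` gives 72 nM, the lowest of the two numbers, and its gap to compound 1 lies beyond the usual scatter, so on these numbers compound 2 needs clearly less material than compound 1.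

Compound 3 `COC/C=C/c1ccc(CN(C(=O)C2CCCCC2)c2cccc(/C=C/C(=O)OC)c2)cc1` has not yet been measured. It differs from compound 2 in one place: 3-methoxyprop-1-en-1-yl in place of 3,4-difluorophenyl on an aromatic carbon. The 3,4-difluorophenyl ring leaves and the open 3-methoxyprop-1-en-1-yl chain enters, on an aromatic carbon of a six-membered aromatic ring of carbon only.

For the measured compounds named here, no pair of measured compounds differing in just one place is available here, so the size of this step cannot be read from a precedent. Given that compound 1, whose group at this position is also not a 3,4-difluorophenyl ring, gives 1470 nM, compound 3 is expected to need more compound than compound 2, and the step of an 8.3-fold higher number from compound 2 to compound 3 (0.92 log units; beyond the scatter) is expected to go beyond the scatter. The estimate for compound 3 in this assay is 600 nM, within a range from 150 nM to 3000 nM.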

Compound 3, half-maximal effective concentration: 233 nM
The estimate for compound 3 lay 2.6-fold (0.41 log units) above the measured number; low and high end bracket the measured number.
By their numbers in this assay, from the lowest: compound 2; then compound 3; then compound 1.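

Measured in this assay the swap of the 3,4-difluorophenyl ring for the open 3-methoxyprop-1-en-1-yl chain gives a 3.2-fold higher number from compound 2 to compound 3 (0.51 log units; beyond the scatter) and so shows that a ring at this position helps but is not essential. Compound 3 has no ring at this place, on a carbon para to a large group, and still gives 233 nM while compound 1, with its different group at the same place, gives 1470 nM and so stands higher on the printed values. Nothing measured here explains the size of this step.

The compounds shown cannot separate the parts of the chain, so it remains open whether its oxygen or its double bond matters, as a saturated 3-methoxypropyl chain or a plain propyl chain would test. From the compounds shown here alone, it also remains open how an unsubstituted phenyl ring, an amine such as a dimethylaminomethyl group or a carboxylic acid at this place would compare with the 3,4-difluorophenyl ring of compound 2.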